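A few compounds are considered here, and "the series" means these few. Any claim that something is new, unique, unknown or untested is made for them only; others in the source may bear on it.

Series notes.

Compound 1, `CCCS(=O)(=O)Nc1ccc(F)c(C(=O)c2n[nH]c3ncc(-c4ccc(C(C)C)cc4)cc23)c1F`, gives 17% in an assay for binding affinity to dual specificity mitogen-activated protein kinase kinase 4 (Homo sapiens), read by KINOMEscan, tested at 100 nM; on this read-out higher numbers stand for a weaker effect at the one concentration tested and lower numbers for a stronger effect.
Compound 2, `CCCS(=O)(=O)Nc1ccc(F)c(C(=O)c2n[nH]c3ncc(-c4cccc(C(F)(F)F)c4)cc23)c1F`, gives 57% in this assay.
Compound 3, `CCCS(=O)(=O)Nc1ccc(F)c(C(=O)c2n[nH]c3ncc(-c4ccc(S(C)(=O)=O)cc4)cc23)c1F`, gives 1.5% in this assay.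

Compound 3 stands lowest of the three in this assay, that is, with the strongest effect: the step of a number 15.5 percentage points lower from compound 1 to compound 3 (beyond the scatter) is modest, the step of a number 55.5 percentage points lower from compound 2 to compound 3 (beyond the scatter) is large, both beyond the scatter. The remaining step, a number 40 percentage points higher from compound 1 to compound 2 (beyond the scatter), shows how far apart the other two aryl substituents lie.

Compound 4, `CCCS(=O)(=O)Nc1ccc(F)c(C(=O)c2n[nH]c3ncc(-c4ccc(S(=O)(=O)NC)cc4)cc23)c1F`, differs from compound 3 in one place: methylamino in place of methyl on a sulfonyl sulfur. For the measured compounds named here, none of the measured steps changes the sulfonyl substituent itself; all three swap the whole group on the aromatic carbon, so they give only the general spread of this series and no direct read on this change. With compound 3 already near the floor of this assay, the step of a number 4.5 percentage points higher from compound 3 to compound 4 (within the scatter) is expected to be small, probably within the scatter, with more room upward than downward. Compound 4 is therefore estimated at 6%, expected range 1% to 25%.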

Compound 4, a percentage reported as activity, at one concentration (the size of the read-out at that concentration, not a potency): 1.2%
Compound 4: middle estimate off by 4.8 percentage points, on the high side; low and high end bracket the measured number.
By their numbers in this assay, from the lowest: compounds 4 and 3 (each within the scatter of the next); then compound 1; then compound 2.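

In this assay the sulfonyl sulfur accepts methylamino in place of methyl with no readable shift: a number 0.3 percentage points lower from compound 3 to compound 4 (within the scatter) gives the first direct read on this substituent, and it does not separate the two. The 4-(methylsulfamoyl)phenyl group also stays clear of the other aryl groups, with a number 15.8 percentage points lower from compound 1 to compound 4 (beyond the scatter) and a number 55.8 percentage points lower from compound 2 to compound 4 (beyond the scatter) both beyond the scatter, so the gap seen for 4-(methylsulfonyl)phenyl survives this change on the sulfur. No measurement at hand bears on the reason for this result.

Both sulfonyl values sit close to the floor at the one concentration tested, so any real difference between them stays hidden. Also open, going by these compounds, is whether a free amino group or a dimethylamino group on the sulfonyl sulfur, or a carboxylic acid on the aromatic carbon instead of the sulfonyl group, would hold the same level.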